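The source may hold more compounds than are shown below. What is called first, only, known or untested is meant among the compounds shown, and "the series" means these compounds.

Three compounds of the shared core have numbers in a functional assay (strain AB) with Danio rerio as the target, read by microscopy, with a stated time of 1 h; a higher number here means that more compound is needed for the effect, a lower number that less compound is needed. Compound 1 `CCN1CCc2c(sc(NC(=O)Nc3ccc4ccccc4c3)c2C(N)=O)C1` gives 1780 nM. Compound 2 `CC[N+]1(C)CCc2c(sc(NC(=O)Nc3ccc(Cl)cc3)c2C(N)=O)C1` gives 1960 nM, and compound 3 `CCN1Cc2sc(NC(=O)Nc3ccc(Cl)cc3)c(C(N)=O)c2C1` gives 4340 nM. Compound 2 stands second highest of the three numbers: its gap to compound 1 is within the scatter, while compound 3 sits beyond the scatter with the higher number. Compound 4 `CC(C)(C)OC(=O)CCCC[N+]1(C)CCc2c(sc(NC(=O)Nc3ccc(Cl)cc3)c2C(N)=O)C1` is not yet measured. It differs from compound 2 by 2-(tert-butoxycarbonyl)ethyl in place of hydrogen on a saturated chain carbon, two bonds along the chain from an amine nitrogen in a ring. For the measured compounds named here, no measured pair shows this change, so nothing here tells its direction. The expected step from compound 2 to compound 4 is a 1.3-fold higher number from compound 2 to compound 4 (0.11 log units; within the scatter), no more than the scatter. Compound 4 is therefore estimated at 2500 nM, with a range from 1000 nM to 6500 nM.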

Compound 4, half-maximal effective concentration: 140 nM
Compound 4: middle estimate off by 18-fold (1.25 log units), on the high side; measured number outside the range, below it.
By their numbers in this assay, from the lowest: compound 4; then compounds 1 and 2 (each within the scatter of the next); then compound 3.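

In this assay, for the compounds shown here, the saturated chain carbon two bonds along the chain from an amine nitrogen in a ring, which no earlier pair had probed, accepts a much larger group: 2-(tert-butoxycarbonyl)ethyl in place of hydrogen gives a 14-fold lower number from compound 2 to compound 4 (1.15 log units; beyond the scatter), a large step in the direction of less compound needed. This rests on a single pair, and nothing measured here accounts for it.

Still open, going by these compounds, is whether the gain needs the ester: a carboxylic acid in place of the tert-butyl ester, or a plain alkyl chain of the same length, would separate the ester from the chain.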